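This account rests on a few compounds, and the source may have more. Where it says the series, first, only, none or still open, it means among the compounds named here.

Series notes. Compound 1 `COc1ccc(-c2cnc(NC(=O)C3CCNCC3)n2C)cc1` is the reference point in a toxicity assay on THP-1 cells (Homo sapiens) for inhibition; on this read-out lower numbers stand for higher toxicity in this test and higher numbers for lower toxicity in this test. For compound 1 the reading is a limit of the assay rather than a number, > 100000 nM. For compound 2 `Cn1cc(-c2ccccc2)nc1NC(=O)c1ccc(F)cc1` the reading in this assay is likewise a limit, > 50000 nM. Among the compounds with values here, compound 1 therefore stands at the low-toxicity end of what has been recorded so far; both values shown are limits, the limit of > 100000 nM in this assay, at which 1 of the 2 values shown sits, and (the limit of > 50000 nM in this assay, at which 1 of the 2 values shown sits), so no step between measured compounds can be sized from them.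

Compound 3 `COc1ccc(-c2cnc(NC(=O)c3ccccc3)n2C)cc1` is the next member to be measured in this assay. It differs from compound 1 in one place: phenyl in place of piperidin-4-yl on a carbonyl carbon. Compound 2, whose reading is the limit > 50000 nM, already carries a phenyl on the carbonyl carbon and is the nearest comparison available for this change.

Expectation: the step of a number no higher from compound 1 to compound 3 (the limit leaves the size open) is estimated to lie within the scatter, with no direction beyond it. Compound 3 is expected to give 100000 nM, within 30000 nM to 300000 nM, and the assay is expected most likely to return only a limit again.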

Compound 3, half-maximal cytotoxic concentration: > 100000 nM
Compound 3 gave a limit, no number; the forecaster's own chance of this, stated with the estimate: 75%; the middle value sits exactly at the limit.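

Compound 1 and compound 3 both return only a limit in this assay, so no step can be read for phenyl in place of piperidin-4-yl on a carbonyl carbon: the limit of > 100000 nM in this assay, at which 2 of the 3 values shown sit.

The compounds shown leave open whether any group on the carbonyl carbon would give a numerical reading in this assay.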